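A few compounds are considered here, and "the series" means these few. Any claim that something is new, unique, unknown or untested is made for them only; others in the source may bear on it.

Measured so far in an assay on isolated protein for agonist activity at Free fatty acid receptor 1 (Homo sapiens); a higher number here means that more compound is needed for the effect, a lower number that less compound is needed:
- compound 1 `CC#CC(CC(=O)O)c1ccc(OCc2ccc3nc(-c4ccc(C(F)(F)F)cc4)cn3c2)cc1`: 558 nM
- compound 2 `CC#CC(CC(=O)O)c1ccc(OCc2ccc3nc(-c4ccccc4)cn3c2)cc1`: 979 nM

Both compounds share the same core and differ only in the group on the outer aromatic ring. The step of a 1.8-fold higher number from compound 1 to compound 2 (0.24 log units; within the scatter) shows that taking away the trifluoromethyl and leaving a bare hydrogen did not move the number beyond the usual scatter, so compound 1 and compound 2 stand at the same level in this assay as far as these two measurements can tell.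

Compound 3 `CC#CC(CC(=O)O)c1ccc(OCc2ccc3nc(-c4ccccc4F)cn3c2)cc1` is not yet measured. It differs from compound 2 by fluoro in place of hydrogen on an aromatic carbon: a single fluorine enters on an aromatic carbon of the six-membered carbon-only ring, ortho to a large group, turning the phenyl into a 2-fluorophenyl. Going by the values given here, the only step that bears on this change is a 1.8-fold higher number from compound 1 to compound 2 (0.24 log units; within the scatter), which concerns a substituent on the same ring and stayed within the scatter. With no other guide, a step of a 1.1-fold lower number from compound 2 to compound 3 (0.04 log units; within the scatter) is expected, meaning no change beyond the scatter. For compound 3 the expected value in this assay is 900 nM, with a range from 350 nM to 2500 nM.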

Compound 3, half-maximal effective concentration: 583 nM
The estimate for compound 3 lay 1.5-fold (0.19 log units) above the measured number, within the range that was stated.
By their numbers in this assay, from the lowest: compounds 1, 3 and 2 (each within the scatter of the next).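

In this assay, fluoro in place of hydrogen on an aromatic carbon, ortho to a large group, gives a 1.7-fold lower number from compound 2 to compound 3 (0.23 log units; within the scatter) and so cannot be told apart from the bare phenyl. Going by these compounds alone, this is the first reading at this position, since the earlier pair concerned only a trifluoromethyl group in the 4-(trifluoromethyl)phenyl. Placing 2-fluorophenyl where 4-(trifluoromethyl)phenyl stood gives a 1.0-fold higher number from compound 1 to compound 3 (0.02 log units; within the scatter) in the same assay, so phenyl, 2-fluorophenyl and 4-(trifluoromethyl)phenyl all stand at one level as far as these three measurements can tell. No other data accompany these numbers that could explain them.

The compounds shown leave open whether any group on this ring can move the number beyond the scatter, for example an amine, a methoxy group or a carboxylic acid. Also open is whether a chlorine in place of this fluoro would stay at the same level, as only one atom has been tried at this position among the compounds shown.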